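Nitro for hydroxy on a pyrazine hydrazone scaffold

This account rests on a few compounds, and the source may have more. Where it says the series, first, only, none or still open, it means among the compounds named here.

Compound 2 `O=C(N/N=C/c1cccc(O)c1)c1cnccn1` has a hydroxy group on the aromatic carbon where compound 1 `O=C(N/N=C/c1ccccc1)c1cnccn1` carries hydrogen. In an ADME assay on J774 cells (Mus musculus) for cytotoxicity, read by MTT assay, with a stated time of 48 h, tested at 50 ug/mL (on this read-out higher numbers stand for a weaker effect at the one concentration tested and lower numbers for a stronger effect), compound 1 gives 100% and compound 2 gives 100%, so compound 2 stands level with compound 1 at the digits shown. Compound 3 `O=C(N/N=C/c1cccc([N+](=O)[O-])c1)c1cnccn1` is not yet measured; the change from compound 2 is nitro in place of hydroxy on an aromatic carbon. Among the measured compounds shown here, the only step at hand, no change at the digits printed from compound 1 to compound 2 (within the scatter), showed no movement. For the measured compounds named here, no step exchanges one substituent for another here, so the expected step of no change at the digits printed from compound 2 to compound 3 (within the scatter) is none beyond the scatter. Compound 3 is therefore estimated at 100%, within 85% to 100%.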

Compound 3, a percentage reported as activity, at one concentration (the size of the read-out at that concentration, not a potency): 100%
Estimate against measurement, compound 3: no gap at the digits printed; the measured number falls inside the stated range.
By their numbers in this assay, from the lowest: compounds 1, 2 and 3 (each within the scatter of the next).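

At the place meta to a large group, a change that swaps a hydrogen-bond donor for a larger nitro group gives no change at the digits printed from compound 2 to compound 3 (within the scatter) in this assay. Set against the hydrogen of the parent, nitro gives no change at the digits printed from compound 1 to compound 3 (within the scatter), so two different substituents at this place now read alike. Nothing at hand explains this flat result.

As far as these compounds go, whether any group at this place can move the read-out stays open, since all three compounds read alike. An amine, a carboxylic acid or a longer chain there remains an open case.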